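The source may hold more compounds than are shown below. What is called first, only, known or untested is meant among the compounds shown, and "the series" means these compounds.

In a functional assay on ECa-109 cells for inhibition, with ECa-109 cell line (Homo sapiens) as the target, read by sulforhodamine B assay (on this read-out higher numbers stand for weaker inhibition and lower numbers for stronger inhibition), compound 1 (`CCCc1ccc(NC2=CC(=O)c3nc4n(c3C2=O)[C@H]2OC[C@@H](O)[C@H]2OC4)cc1`) gives > 4000 nM as a limit of the assay. Compound 2 (`COc1ccc(NC2=CC(=O)c3nc4n(c3C2=O)[C@H]2OC[C@@H](O)[C@H]2OC4)cc1`) gives > 4000 nM which is also a limit, so it has no number of its own. Within the data shown here, the only measured change is a step that the two limits leave unreadable from compound 1 to compound 2 and it offers no size to carry forward. Among the measured compounds shown here, in compound 3 (`CCOc1ccccc1NC1=CC(=O)c2nc3n(c2C1=O)[C@H]1OC[C@@H](O)[C@H]1OC3`) the change from compound 2 is 2-ethoxyphenyl in place of 4-methoxyphenyl on an amine nitrogen and no sized step bears on it. For the measured compounds named here, no step of definite size or direction is expected in this assay because of the limit of > 4000 nM in this assay, at which 2 of the 2 values shown sit, and a further limit is the likeliest outcome. The estimated step is a step that the limit leaves unreadable from compound 2 to compound 3 and it remains uncertain. Compound 3 is expected near 5000 nM within an estimated range of 1500 nM to 15000 nM on this read-out.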

Compound 3, half-maximal inhibitory concentration: 4630 nM
The estimate for compound 3 lay 1.1-fold (0.03 log units) above the measured number; the range from low to high includes it.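

Among these compounds, no step to compound 3 can be read from compound 1 or compound 2, because both of those compounds sit at a limit of the assay: the limit of > 4000 nM in this assay, at which 2 of the 3 values shown sit. The compounds shown leave open how far either lies from compound 3 in this assay.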